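A Second Fluoro Group Added to the Shared Core

The source may hold more compounds than are shown below. What is called first, only, known or untested is meant among the compounds shown, and "the series" means these compounds.

Measured compounds:
compound 1, `C[C@@H](NC(=O)Nc1ccccc1F)c1ccccc1`, giving 97%
compound 2, `C[C@@H](NC(=O)Nc1ccc(F)cc1)c1ccccc1`, giving 98%

Both compounds were tested in an ADME assay on the whole organism with Oryza sativa as the target, tested at 0.1 uM; on this read-out lower numbers stand for a stronger effect and higher numbers for a weaker effect at the one concentration tested. In this assay compound 1 gives 97%, and in the same setting compound 2 gives 98%. Compound 2 has the highest of the two numbers, but its nearest neighbour, compound 1, lies only a small amount lower, a gap that falls within the usual scatter of repeated measurements, so the two compounds cannot be told apart on this read-out. Both numbers sit close to the top of the scale, which on this read-out means a weak effect at the one concentration tested.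

The next compound is compound 3, `C[C@@H](NC(=O)Nc1ccc(F)cc1F)c1ccccc1`, which has not yet been measured in this assay. Compared with compound 2 it differs in one place: fluoro in place of hydrogen on an aromatic carbon.

Going by the values given here, no step between measured compounds is available to guide a forecast, so the expectation rests on compound 2 alone. With compound 2 already near the top of the scale, the step of a number 2 percentage points lower from compound 2 to compound 3 (within the scatter) is expected to be no larger than the scatter, and a rise cannot go far. For compound 3 the estimated value in this assay is 96%, with a range from 85% to 100%.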

Compound 3, a percentage reported as activity, at one concentration (the size of the read-out at that concentration, not a potency): 100%
Beside the measured number, compound 3's estimate is 4 percentage points below it; measured number inside the range.
By their numbers in this assay, from the lowest: compounds 1, 2 and 3 (each within the scatter of the next).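

In this assay, putting a fluoro group on an aromatic carbon that is ortho to a large group and meta to the fluoro group already present gives a number 2 percentage points higher from compound 2 to compound 3 (within the scatter), so at this position a second fluoro group brings no difference that can be told from the scatter. The same kind of replacement, read from the other compound with a single fluoro group, gives a number 3 percentage points higher from compound 1 to compound 3 (within the scatter), and together these two steps show something the earlier pair could not: going from one fluoro group to two leaves this read-out close to the top of the scale, where it stands for a weak effect at the one concentration tested. No measurement at hand speaks to why the numbers stay so close together.

The compounds shown carry only hydrogen and fluoro groups on this aromatic ring, so it stays open whether any replacement there can bring the number clearly down, toward a stronger effect. A chlorine, a methoxy group or an amine at this same position could answer that, as could a change elsewhere on the shared core.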